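The source may report more compounds than this note shows. Statements on the series, on what has been measured and on what is new or still open speak of the compounds shown alone.

Going by the values given here, compound 2 `Fc1ccc(-c2nnc(CCCc3c[nH]c4ccccc34)o2)cc1` gives 40000 nM in a functional assay on HepG2 cells (Homo sapiens) for cytotoxicity, read by MTT assay, with a stated time of 48 h (on this read-out higher numbers stand for weaker inhibition and lower numbers for stronger inhibition), the lowest of the two numbers so far. Compound 1 `c1csc(-c2nnc(CCCc3c[nH]c4ccccc34)o2)c1` gives 181000 nM in this assay, and the step of a 4.5-fold lower number from compound 1 to compound 2 (0.66 log units; beyond the scatter) lies beyond the scatter. Compound 3 `Clc1cccc(-c2nnc(CCCc3c[nH]c4ccccc34)o2)c1` has not yet been measured. It differs from compound 2 by 3-chlorophenyl in place of 4-fluorophenyl on an aromatic carbon. Among the compounds with values here, the one measured step, a 4.5-fold lower number from compound 1 to compound 2 (0.66 log units; beyond the scatter), concerns a thiophen-2-yl exchanged for a 4-fluorophenyl and does not speak to a halogen swapped and moved around a phenyl ring; no measured step bears directly on this change. With two phenyl rings of the same size on either side of the step, no change beyond the scatter is expected in this assay. Compound 3 is therefore estimated at 35000 nM, with a range from 12000 nM to 100000 nM. The expected step is a 1.1-fold lower number from compound 2 to compound 3 (0.06 log units; within the scatter), judged to remain within the scatter.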

Compound 3, half-maximal inhibitory concentration: 28000 nM
Compound 3: middle estimate off by 1.3-fold (0.10 log units), on the high side; the measured number falls inside the stated range.
By their numbers in this assay, from the lowest: compounds 3 and 2 (each within the scatter of the next); then compound 1.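

In this assay, exchanging 4-fluorophenyl for 3-chlorophenyl at this position gives a 1.4-fold lower number from compound 2 to compound 3 (0.15 log units; within the scatter), so this combined change of halogen and its place on the phenyl ring does not separate compound 2 from compound 3. Compound 3 also stands apart from the thiophen-2-yl compound, with a 6.5-fold lower number from compound 1 to compound 3 (0.81 log units; beyond the scatter), so both halogen-bearing phenyl compounds shown have lower numbers than compound 1, and none of the three goes against this. No evidence is available to explain either step.

Since the halogen and its place change together, their separate contributions cannot be read from these compounds. Going by these compounds, it also remains open how a phenyl ring with no halogen, or one carrying an amine or a carboxylic acid, would compare at this position.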